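A few compounds are considered here, and "the series" means these few. Any claim that something is new, unique, unknown or untested is made for them only; others in the source may bear on it.

Compound 1 `CN(C)C[C@H]1CN(C)C(=O)O1` and compound 3 `CN(C)C[C@H]1CNC(=O)O1` share one core, and compound 3 carries hydrogen in place of methyl on an amide-type nitrogen in a ring. In an assay on CHO cells for displacement of a labelled ligand from muscarinic acetylcholine receptor M5 (Homo sapiens) (a lower number here means a stronger inhibitor, a higher number a weaker inhibitor), compound 1 gives only a limit of the assay, > 100000 nM. In this assay compound 3 also gives only a limit, > 100000 nM. The step that the two limits leave unreadable from compound 1 to compound 3 thus cannot be read. Compound 2 `CN1C[C@@H](C[N+](C)(C)C)OC1=O` has another core; how it differs from compound 1 is not broken down here. In this assay compound 2 gives only a limit, > 100000 nM. Compound 4 `C[N+](C)(C)C[C@@H]1CNC(=O)O1` carries hydrogen in place of methyl on an amide-type nitrogen in a ring. This is the same kind of change as that from compound 1 to compound 3, not the same, since here the ring atom bears a group of 5 heavy atoms rather than 4. Because (the limit of > 100000 nM in this assay, at which 3 of the 3 values shown sit), the step from compound 2 to compound 4 is expected to be a step that the limit leaves unreadable from compound 2 to compound 4. Compound 4 is expected to give 150000 nM, most likely again only a limit.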

Compound 4, inhibition constant: > 100000 nM
Compound 4 ended at the assay's limit; the forecaster's own chance of this, stated with the estimate: 90%; the middle value lies beyond the limit too.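

Compound 2 and compound 4 both end at a limit of the assay, and the step between them cannot be read. The compounds shown leave open whether hydrogen in place of methyl on the amide-type nitrogen changes anything in this assay, where each gives only a limit.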